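A longer arm on compound 2: expected cytotoxicity

This account rests on a few compounds, and the source may have more. Where it says the series, first, only, none or still open, it means among the compounds named here.

Measured so far in an ADME assay on THP-1 cells (Homo sapiens) for cytotoxicity, read by flow cytometry, with a stated time of 72 h; on this read-out lower numbers stand for stronger inhibition and higher numbers for weaker inhibition:
compound 1 `N/C(=N\O)c1ccc(S(=O)(=O)C2=C(c3ccccc3)OC(c3ccccc3)(c3ccccc3)C2)cc1` gives 37900 nM
compound 2 `N/C(=N\O)c1ccc(C2=C(S(=O)(=O)c3ccc(/C(N)=N/O)cc3)CC(c3ccccc3)(c3ccccc3)O2)cc1` gives 119000 nM

Among the measured compounds shown here, compound 2 stands highest of the two numbers in this assay; its nearest neighbour is compound 1, and the only step between measured compounds is a 3.1-fold higher number from compound 1 to compound 2 (0.50 log units; beyond the scatter). That step placed a group of 4 heavy atoms (1 carbon, 2 nitrogen, 1 oxygen; no ring) on an aromatic carbon and raised the number modestly, beyond the scatter.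

Compound 3 `N/C(=N\O)c1ccc(/C=C/c2ccc(S(=O)(=O)C3=C(c4ccc(/C(N)=N/O)cc4)OC(c4ccccc4)(c4ccccc4)C3)cc2)cc1` has not been measured. It differs from compound 2 in one place: a group of 12 heavy atoms (9 carbon, 2 nitrogen, 1 oxygen; one six-membered aromatic ring of carbon only) in place of a group of 4 heavy atoms (1 carbon, 2 nitrogen, 1 oxygen; no ring), on an aromatic carbon. The group that leaves is the very one whose arrival defined the step from compound 1 to compound 2, and the group that enters is larger and carries one six-membered aromatic ring of carbon only.

For the measured compounds named here, the single measured step concerns an addition, not an exchange, so the reviewer takes it as weak guidance only. The reviewer expects for compound 3 a step of a 1.2-fold lower number from compound 2 to compound 3 (0.08 log units; within the scatter) in this assay, meaning no change beyond the scatter. The reviewer's estimate for compound 3 in this assay is 100000 nM, with a range from 40000 nM to 250000 nM.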

Compound 3, half-maximal inhibitory concentration: > 10000 nM
Compound 3: a limit, no number; the forecaster's own chance of this, stated with the estimate: 30%; the middle value is on the limit's open side.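

Compound 3 is reported only as a limit, not as a number: the limit of > 10000 nM in this assay, at which 1 of the 3 values shown sits. Among the compounds shown here, no step from compound 2 to compound 3 can be read from it. The compounds shown leave open whether the larger group, with its one six-membered aromatic ring of carbon only, changes the cytotoxicity read-out relative to compound 2, and in which direction.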